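Removing the aminooxy terminus from the most potent analogue

A few compounds are considered here, and "the series" means these few. Any claim that something is new, unique, unknown or untested is made for them only; others in the source may bear on it.

The series shares one core, a nucleoside bearing a tertiary amine on its sugar chain. Compound 3 `Cc1nc2c(N)ncnc2n1[C@@H]1O[C@H](CN(C)CCCCON)[C@@H](O)[C@H]1O` carries a chain ending in an aminooxy group; in an assay on isolated protein for inhibition of S-adenosylmethionine decarboxylase proenzyme (Homo sapiens) (a higher number here means a weaker inhibitor, a lower number a stronger inhibitor), compound 3 gives 5 nM, the lowest of the three numbers shown. Compound 1 `Cc1nc2c(N)ncnc2n1[C@@H]1O[C@H](CN(C)CCN)[C@@H](O)[C@H]1O` ends in a shorter amine-terminated chain and gives 88000 nM. Compound 2 `CNc1nc2c(N)ncnc2n1[C@@H]1O[C@H](CN(C)CCCN)[C@@H](O)[C@H]1O` has methylamino on the core and an amine-terminated chain, and gives 440000 nM.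

Compound 4 `Cc1nc2c(N)ncnc2n1[C@@H]1O[C@H](CN(C)CCCN)[C@@H](O)[C@H]1O` is not yet measured. It differs from compound 3 by amino in place of (aminooxy)methyl on a saturated chain carbon, three bonds along the chain from an amine nitrogen; the whole chain, cut one bond further out, changes from 4-(aminooxy)butyl to 3-aminopropyl.

Within the data shown here, the one measured step that bears directly on this change runs the opposite way: an 18000-fold lower number from compound 1 to compound 3 (4.25 log units; beyond the scatter). The values of compound 1 and compound 2 both show that amine-terminated chains on this core sit far above compound 3. A large increase in this assay is therefore expected.

The estimated step is a 20000-fold higher number from compound 3 to compound 4 (4.30 log units; beyond the scatter), because the reverse change gave an 18000-fold lower number from compound 1 to compound 3 (4.25 log units; beyond the scatter). For compound 4 the expected value is 100000 nM, with a range from 25000 nM to 400000 nM.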

Compound 4, half-maximal inhibitory concentration: 70000 nM
Compound 4: middle estimate off by 1.4-fold (0.15 log units), on the high side; measured number inside the range.
By their numbers in this assay, from the lowest: compound 3; then compounds 4 and 1 (each within the scatter of the next); then compound 2.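

In this assay, amino in place of (aminooxy)methyl on a saturated chain carbon, three bonds along the chain from an amine nitrogen, gives a 14000-fold higher number from compound 3 to compound 4 (4.15 log units; beyond the scatter) and thus supplies the direct comparison for this change at this chain length. Aminomethyl in place of amino gives a 1.3-fold lower number from compound 1 to compound 4 (0.10 log units; within the scatter) which is within the scatter, so among these amine-terminated chains, the 3-aminopropyl chain and the shorter chain of compound 1 cannot be told apart, and chain extension alone does not reproduce the number of compound 3. Methyl in place of methylamino on an aromatic carbon gives a 6.3-fold lower number from compound 2 to compound 4 (0.80 log units; beyond the scatter) which is beyond the scatter but modest, so the core substituent also counts, on a far smaller scale than the change at the chain end.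

Nothing available explains the size of the change at the chain end. The compounds shown leave open whether a longer chain ending in an amine, or a chain ending in a hydroxyl group, would stay near compound 4 or approach compound 3, and how methylamino on the core would act alongside the 4-(aminooxy)butyl chain.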